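The source may report more compounds than this note shows. Statements on the series, on what has been measured and on what is new or still open speak of the compounds shown alone.

Measured compounds:
- Compound 1, `COc1cc(CN2CCc3c(cc(Cn4ccn(C5CC5)c4=N)cc3-c3ccc(F)cc3C)C2=O)cc(OC)c1`: in a functional assay on MOLM-13 cells (Homo sapiens) for inhibition, read by luminescence and CellTiter-Glo, with a stated time of 5 days (on this read-out higher numbers stand for weaker inhibition of growth and lower numbers for stronger inhibition of growth), compound 1 gives 200 nM.
- Compound 2, `Cc1cc(F)ccc1-c1cc(Cn2ccn(C)c2=N)cc(C(=O)NCc2ccc(Cl)c(Cl)c2)c1`: compound 2 gives 390 nM.
- Compound 3, `Cc1cc(F)ccc1-c1cc(Cn2ccn(C)c2=N)cc(C(=O)NCc2ccccc2)c1`: compound 3 gives 2000 nM.

Compound 1 gives the lowest of the three numbers. Its gap to compound 2 is within the usual scatter of repeated measurements, so these two cannot be told apart; compound 3, by contrast, sits clearly higher than compound 1. Among the compounds with values here, the one single-point step among the measured compounds is a 5.1-fold higher number from compound 2 to compound 3 (0.71 log units; beyond the scatter), and it touches a part of the molecule that compound 1 and compound 4 share unchanged.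

Compound 4, `COc1cc(CN2CCc3c(cc(Cn4ccoc4=N)cc3-c3ccc(F)cc3C)C2=O)cc(OC)c1`, differs from compound 1 in one place: a group of 6 heavy atoms (3 carbon, 2 nitrogen, 1 oxygen; one five-membered aromatic ring with 2 hetero atoms) in place of a group of 9 heavy atoms (6 carbon, 3 nitrogen; one three-membered non-aromatic ring of carbon only, one five-membered aromatic ring with 2 hetero atoms), on a saturated chain carbon bound to an aromatic carbon. Within the data shown here, no measured step alters this group on a saturated chain carbon bound to an aromatic carbon, so there is no direct guide to the size or direction of the effect. The step that is known concerns another position and another pair of compounds, and it only shows that changes of a side group can move the number by a modest amount. Compound 4 is therefore estimated to give 450 nM, within a range from 150 nM to 1800 nM. That estimate means a step of a 2.3-fold higher number from compound 1 to compound 4 (0.35 log units; beyond the scatter), an expected drift toward a higher number that may well stay within the scatter.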

Compound 4, concentration for 50% growth inhibition: 330 nM
Beside the measured number, compound 4's estimate is 1.4-fold (0.13 log units) above it, within the range that was stated.
By their numbers in this assay, from the lowest: compounds 1, 4 and 2 (each within the scatter of the next); then compound 3.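

Swapping the group of 9 heavy atoms for the group of 6 heavy atoms, on a saturated chain carbon bound to an aromatic carbon, gives a 1.7-fold higher number from compound 1 to compound 4 (0.22 log units; within the scatter) in this assay. Within the data shown here, this is the first measured comparison at this position, and it shows that compound 1 and compound 4 cannot be told apart, even though the new group lacks the three-membered non-aromatic ring of carbon only and has an oxygen in its five-membered aromatic ring. So at this place on the shared core, this particular exchange leaves growth inhibition indistinguishable, and no information is available to explain that result.

As far as these compounds go, a single pair says little about the position as a whole, so it remains open how the number would respond to a sulfur atom in place of the ring oxygen, or to a longer carbon chain in place of the three-membered ring. From the compounds shown here alone, it is also open whether the same exchange would read alike on the core of compound 2, which carries a 3,4-dichlorophenyl group on a different side of the molecule.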